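The compounds below may be only part of what the source reports. "The series", "measured", "known", "first", "only" and "open" are said of these compounds alone.

In a functional assay on DU-145 cells (Homo sapiens) for inhibition, read by trypan blue exclusion, with a stated time of 96 h (on this read-out lower numbers stand for stronger inhibition of growth and higher numbers for weaker inhibition of growth), compound 1 `Cc1ccc(CS/C(=C/c2c(O)cc(O)cc2O)C(=O)c2ccc(Cl)cc2)cc1` gives 50000 nM, level with compound 2 `O=C(/C(=C\c1c(O)cc(O)cc1O)S(=O)(=O)c1ccccc1Br)c1ccc(Cl)cc1` at 50000 nM and compound 3 `Cc1ccsc1/C=C(/SCc1ccc(Cl)c(Cl)c1)C(=O)c1ccc(Cl)cc1` at 50000 nM. The numbers therefore show no spread among the measured compounds. Compound 4 `Cc1ccc(CS/C(=C/c2ccccc2F)C(=O)c2ccc(Cl)cc2)cc1` departs from compound 1 at a single place, on a double-bonded chain carbon bound to a double-bonded chain carbon: 2-fluorophenyl in place of 2,4,6-trihydroxyphenyl on a double-bonded chain carbon bound to a double-bonded chain carbon. Among the measured compounds shown here, the only measured step in one place shows no change at the digits printed from compound 1 to compound 2 (within the scatter), but it concerns another part of the molecule and keeps the 2,4,6-trihydroxyphenyl group, so it bears on the new change only indirectly. Closer evidence comes from compound 3, which also lacks 2,4,6-trihydroxyphenyl and still gives 50000 nM. For the measured compounds named here, no measured compound carries 2-fluorophenyl, so the data cannot exclude some stronger inhibition of growth in this assay. Even so, no shift beyond the scatter is expected. The expected step is a 1.3-fold lower number from compound 1 to compound 4 (0.10 log units; within the scatter). For compound 4 the estimated value is 40000 nM, with an expected range from 10000 nM to 60000 nM.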

Compound 4, concentration for 50% growth inhibition: 10000 nM
Estimate against measurement, compound 4: 4.0-fold (0.60 log units) above, within the range that was stated.
By their numbers in this assay, from the lowest: compound 4; then compounds 1, 2 and 3 (each within the scatter of the next).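

Exchanging 2,4,6-trihydroxyphenyl for 2-fluorophenyl on a double-bonded chain carbon bound to a double-bonded chain carbon gives a 5.0-fold lower number from compound 1 to compound 4 (0.70 log units; beyond the scatter) in this assay. Among the compounds shown here, this shows that the number responds to the group at this position, which the only earlier step in one place, no change at the digits printed from compound 1 to compound 2 (within the scatter), could not show, as it concerned another part of the molecule. The change removes a group with 3 hydrogen-bond donors and brings in fluorine at once, and nothing measured here explains the lower number.

On these data alone, it remains open whether an unsubstituted phenyl, a 2-chlorophenyl or a 2-methoxyphenyl at this position would give a similar number, which would help separate the loss of the hydroxyl groups from the entry of fluorine. Also open, as far as these compounds go, is whether the same exchange would lower the number with the (2-bromophenyl)sulfonyl group of compound 2 in the molecule.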